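Piperidine in Place of Pyridine on the Ester Carbonyl

A few compounds are considered here, and "the series" means these few. Any claim that something is new, unique, unknown or untested is made for them only; others in the source may bear on it.

Compound 1 `O=C(OC1=C(c2cccc3ncccc23)Oc2cc3ccccc3cc2-n2cccc21)c1cccnc1` is one of three esters sharing a common core. In a functional assay on NIH3T3 cells (Mus musculus) for inhibition, read by neutral red uptake, with a stated time of 24 h (a lower number here means that less compound is needed, a higher number that more compound is needed for the effect), compound 1 gives 6000 nM, level at the digits shown with compound 3 `CC(C)(C)OC(=O)N1CCC(C(=O)OC2=C(c3cccc4ncccc34)Oc3cc4ccccc4cc3-n3cccc32)CC1`, which gives 6000 nM; together they are the highest of the three numbers, while compound 2 `CN1CCN(C(=O)OC2=C(c3cccc4ncccc34)Oc3cc4ccccc4cc3-n3cccc32)CC1` gives 450 nM. Among the compounds with values here, the one measured step that bears here, a 13-fold lower number from compound 1 to compound 2 (1.12 log units; beyond the scatter), is large. Compound 4 `O=C(OC1=C(c2cccc3ncccc23)Oc2cc3ccccc3cc2-n2cccc21)C1CCNCC1` differs from compound 1 by piperidin-4-yl in place of pyridin-3-yl on a carbonyl carbon. Since the change resembles that from compound 1 to compound 2, where the number dropped a 13-fold lower number from compound 1 to compound 2 (1.12 log units; beyond the scatter), a lower number is expected for compound 4, though perhaps less than the full step; the step expected is a 5.0-fold lower number from compound 1 to compound 4 (0.70 log units; beyond the scatter). Compound 4 is therefore estimated at 1200 nM, within 300 nM to 4500 nM.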

Compound 4, half-maximal effective concentration: 600 nM
Beside the measured number, compound 4's estimate is 2.0-fold (0.30 log units) above it; the measured number falls inside the stated range.
By their numbers in this assay, from the lowest: compounds 2 and 4 (each within the scatter of the next); then compounds 1 and 3 (each within the scatter of the next).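

In this assay, piperidin-4-yl in place of pyridin-3-yl gives a 10-fold lower number from compound 1 to compound 4 (1.00 log units; beyond the scatter), so the fall seen with 4-methylpiperazin-1-yl does not require that group, and the two groups are not separated: a 1.3-fold higher number from compound 2 to compound 4 (0.12 log units; within the scatter). On the amine nitrogen in the ring, hydrogen in place of tert-butoxycarbonyl gives a 10-fold lower number from compound 3 to compound 4 (1.00 log units; beyond the scatter), so the carbamate-capped piperidine of compound 3 does not carry this gain. Nothing available here explains these steps.

Going by these compounds, whether a 1-methylpiperidin-4-yl group or an unsubstituted piperazin-1-yl group on the carbonyl carbon would hold the number of compound 4 remains open. So does the effect of an open-chain amine there.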